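A few compounds are considered here, and "the series" means these few. Any claim that something is new, unique, unknown or untested is made for them only; others in the source may bear on it.

Measured so far:
Compound 1 `Cn1cc(-c2cnc(NCc3c(F)ccc4c3CCO4)c3cn[nH]c(=O)c23)cn1`: 1000 nM
Compound 2 `CN(C)Cc1ccc(C(=O)Nc2cnc(NCc3c(F)ccc4c3CCO4)n3cnnc23)cc1`: 520000 nM

Both compounds were tested in a physicochemical assay for solubility, read by LC-MS, in phosphate buffer, with a stated time of 24 h, at pH 7.4; on this read-out higher numbers stand for higher solubility and lower numbers for lower solubility. Compound 1 gives 1000 nM, and compound 2 gives 520000 nM. On these two numbers compound 1 stands lowest; compound 2 shows a much higher number, a gap well beyond the usual scatter. Compound 2 is built on a different core, so its value says nothing direct about what a single change to compound 1 would do.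

The compound not yet measured is compound 3 `CN(c1ccn(C)n1)c1cnc(NCc2c(F)ccc3c2CCO3)c2cn[nH]c(=O)c12`. It differs from compound 1 in one place: methyl(1-methyl-1H-pyrazol-3-yl)amino in place of 1-methyl-1H-pyrazol-4-yl on an aromatic carbon. Among the compounds with values here, no measured pair shows this change, so the expectation rests on compound 1 alone. The entering group is larger and carries one more acceptor, but nothing measured here ties such a change to a known step in this assay. A modest rise is expected, though one that may stay within the scatter.

The step of a 2.5-fold higher number from compound 1 to compound 3 (0.40 log units; beyond the scatter) is expected to be small and upward. Compound 3 is estimated to give 2500 nM, within a range from 600 nM to 12000 nM.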

Compound 3, solubility: 12000 nM
For compound 3 the middle estimate is 4.8-fold (0.68 log units) below the measured one; the range from low to high includes it.
By their numbers in this assay, from the lowest: compound 1; then compound 3; then compound 2.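

In this assay, within the data shown here, placing methyl(1-methyl-1H-pyrazol-3-yl)amino in place of 1-methyl-1H-pyrazol-4-yl on this aromatic carbon gives a 12-fold higher number from compound 1 to compound 3 (1.08 log units; beyond the scatter), a large step and the first one seen between compounds that differ in one place. It shows that this position, para to a large group, can shift the read-out markedly while the rest of the molecule stays fixed, even though both groups hold one five-membered aromatic ring with 2 hetero atoms and carry no net charge. The entering group has 8 heavy atoms against 6 and 3 hydrogen-bond acceptors against 2, but no measurement on hand explains why the number moves.

This single pair cannot separate the parts of the swap. Among these compounds, the ring, its point of attachment and the extra methyl on nitrogen all change together here, and no measured compound varies them one at a time. A morpholine or a carboxylic acid on the same aromatic carbon would show whether the rise is tied to this pyrazole group or also appears with quite different groups.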